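This account rests on a few compounds, and the source may have more. Where it says the series, first, only, none or still open, it means among the compounds named here.

Compound 1 `COc1ccc2c(c1)OC(c1cc(OC)c(OC)c(OC)c1)C(C=O)=C2`: in a functional assay for inhibition of nuclear factor NF-kappa-B complex (Homo sapiens) (on this read-out lower numbers stand for stronger inhibition and higher numbers for weaker inhibition), compound 1 gives 13500 nM.
Compound 2 `CCCC(=O)C1=Cc2ccc(OC)cc2OC1c1cc(OC)c(OC)c(OC)c1`: in this assay compound 2 gives 11700 nM.

Compound 2 has the lower of the two numbers, but only by a 1.2-fold lower number from compound 1 to compound 2 (0.06 log units; within the scatter), which lies within the scatter. Compound 3 `CNC(=O)C1=Cc2ccc(OC)cc2OC1c1cc(OC)c(OC)c(OC)c1` differs from compound 2 as follows: methylamino in place of propyl on a carbonyl carbon. Among the compounds with values here, the only step that bears on this change is the one at the same carbonyl carbon, from compound 1 to compound 2, and it produced nothing beyond the scatter. Nothing here shows what a methylamino group does at that place. Compound 3 is therefore expected to stay close, with a step of a 1.0-fold higher number from compound 2 to compound 3 (0.01 log units; within the scatter), and its estimated value is 12000 nM, within a range of 4000 nM to 40000 nM.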

Compound 3, half-maximal inhibitory concentration: > 50000 nM
Compound 3 was reported as a limit; the forecaster's own chance of this, stated with the estimate: 15%; middle value at least 4.1-fold (0.61 log units) away from the limit.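

The carbonyl carbon is not indifferent to what it carries, which the step from hydrogen to propyl alone did not reveal. Methylamino in place of propyl gives an at least 4.2-fold higher number from compound 2 to compound 3 (0.63 log units; beyond the scatter), and methylamino in place of hydrogen gives an at least 3.7-fold higher number from compound 1 to compound 3 (0.56 log units; beyond the scatter). In this assay compound 3 is reported only as a limit of the assay, not as a number: the limit of > 50000 nM in this assay, at which 1 of the 3 values shown sits.

The compounds shown leave open whether this weakening follows the nitrogen or the amide hydrogen. A dimethylamino or a methoxy group on the same carbonyl carbon would separate the two.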